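Two Limits and an Untested Chlorophenyl Analogue

This account rests on a few compounds, and the source may have more. Where it says the series, first, only, none or still open, it means among the compounds named here.

Compound 1 `FC(F)(F)c1ccc(CSc2nc(Nc3ccccc3Cl)c3ccccc3n2)cc1` and compound 2 `CCOc1ccccc1Nc1nc(SCc2ccc(C(F)(F)F)cc2)nc2ccccc12` share one core and differ at a single point: a step that the two limits leave unreadable from compound 1 to compound 2. In a functional assay on MDA-MB-231 cells (Homo sapiens) for cytotoxicity, read by MTT assay, with a stated time of 72 h (on this read-out lower numbers stand for stronger inhibition and higher numbers for weaker inhibition), compound 1 reaches only the limit of > 50000 nM, so no number is known for it. In this assay compound 2 likewise reaches only the limit of > 50000 nM. Both compounds thus sit at the limit of > 50000 nM in this assay, at which 2 of the 2 values shown sit, and the step between them cannot be sized.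

Compound 3 `FC(F)(F)c1ccc(CSc2nc(Nc3cccc(Cl)c3)c3ccccc3n2)cc1` has not yet been tested. Relative to compound 2 it carries 3-chlorophenyl in place of 2-ethoxyphenyl on a nitrogen on an aromatic ring. Within the data shown here, the only measured step concerns the same nitrogen, but its size is not readable because of the limit of > 50000 nM in this assay, at which 2 of the 2 values shown sit, so it gives no direction for the change to compound 3. With both measured compounds at the limit, no step beyond the scatter can be foreseen, and the most likely outcome is that compound 3 also reports only a limit. Compound 3 is therefore expected to give about 60000 nM in this assay, within 15000 nM to 200000 nM. The estimated step would then be a step that the limit leaves unreadable from compound 2 to compound 3.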

Compound 3, half-maximal inhibitory concentration: 18000 nM
Estimate against measurement, compound 3: 3.3-fold (0.52 log units) above; the range from low to high includes it.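

In this assay, this position on the nitrogen gives its first readable result, as 3-chlorophenyl in place of 2-ethoxyphenyl produces an at least 2.7-fold lower number from compound 2 to compound 3 (0.44 log units; beyond the scatter). Changing only 2-chlorophenyl to 3-chlorophenyl, with the chlorine kept on the ring, produces an at least 2.7-fold lower number from compound 1 to compound 3 (0.44 log units; beyond the scatter), so these two chlorophenyl groups are not interchangeable in this assay and the position can respond to a change in the group it carries. Both steps are minimum sizes and the true gaps could be wider, because the compounds at the start of each step give no number, only a limit: the limit of > 50000 nM in this assay, at which 2 of the 3 values shown sit.

As far as these compounds go, with a single measured number in the set, it remains open whether the gain depends on chlorine itself or would also appear with another group in the same place, such as 3-methoxyphenyl, 3-fluorophenyl or 3-aminophenyl. From the compounds shown here alone, it is also open how a 4-chlorophenyl group on the same nitrogen would read, and so whether the result of compound 3 is specific to 3-chlorophenyl or extends to other chlorophenyl groups.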